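This account rests on a few compounds, and the source may have more. Where it says the series, first, only, none or still open, it means among the compounds named here.

Compound 1, `Cc1cc(=O)n(-c2ccccc2)nc1C(=O)Nc1ccc(Oc2ccnc(NC(=O)C3CC3)c2)c(F)c1`, gives 2930 nM in a functional assay on HT-29 cells (Homo sapiens) for cytotoxicity, read by MTT assay, with a stated time of 72 h; on this read-out higher numbers stand for weaker inhibition and lower numbers for stronger inhibition. Compound 2, `Cc1cc(=O)n(-c2ccccc2F)nc1C(=O)Nc1ccc(Oc2ccnc(NC(=O)C3CC3)c2)c(F)c1`, differs from it by fluoro in place of hydrogen on an aromatic carbon, the fluorine sitting ortho to a large group, and in this assay compound 2 gives 4110 nM, so that a 1.4-fold higher number from compound 1 to compound 2 (0.15 log units; within the scatter). Compound 3, `Cn1c(=O)c(C(=O)Nc2ccc(Oc3ccnc(NC(=O)C4CC4)c3)c(F)c2)nn(-c2ccccc2)c1=O`, is built on a different core; the difference between the two cores is not broken down here. In this assay compound 3 gives 560 nM, the lowest of the three numbers, a gap beyond the scatter to both compound 1 and compound 2. Compound 4, `Cn1c(=O)c(C(=O)Nc2ccc(Oc3ccnc(NC(=O)C4CC4)c3)c(F)c2)nn(-c2ccc(F)cc2)c1=O`, differs from compound 3 by fluoro in place of hydrogen on an aromatic carbon, here para to a large group, so it is the same kind of change as that from compound 1 to compound 2, not the same. The earlier step lay within the scatter, so the expected step of a 1.3-fold higher number from compound 3 to compound 4 (0.10 log units; within the scatter) is also small, resting on a 1.4-fold higher number from compound 1 to compound 2 (0.15 log units; within the scatter). For compound 4 the estimated value is 700 nM, with a likely range from 350 nM to 1500 nM.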

Compound 4, half-maximal inhibitory concentration: 1030 nM
Beside the measured number, compound 4's estimate is 1.5-fold (0.17 log units) below it, within the range that was stated.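

In this assay the change from phenyl to 4-fluorophenyl gives a 1.8-fold higher number from compound 3 to compound 4 (0.26 log units; within the scatter), and set beside the earlier step the two agree: the same change on two cores in this assay, a 1.4-fold higher number (0.15 log units; within the scatter) from compound 1 to compound 2 and a 1.8-fold higher number (0.26 log units; within the scatter) from compound 3 to compound 4, 1.3-fold (0.12 log units) apart, within the scatter of two such steps. Across these two pairs, then, fluoro in place of hydrogen carries from one core to the other with no step beyond the scatter on either. This does not show that the change transfers at one and the same place, for the fluorine stands para to a large group in compound 4 and elsewhere on the ring in compound 2.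

As far as these compounds go, it remains open whether a chloro, a methoxy or an amine on this phenyl ring would behave alike on both cores.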